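This account rests on a few compounds, and the source may have more. Where it says the series, first, only, none or still open, it means among the compounds named here.

Working notes on the series.

Compound 2 `N#Cc1c(Nc2ccccc2Cl)nc(SCc2cn(Cc3ccccc3Cl)nn2)nc1-c1ccccc1` and compound 1 `C#CCSc1nc(Nc2cccc(Cl)c2)c(C#N)c(-c2ccccc2)n1` share a core and are both weak in a functional assay on B16-F10 cells (Mus musculus) for inhibition, read by MTT assay, with a stated time of 72 h; a lower number here means a stronger inhibitor, a higher number a weaker inhibitor. Compound 2 gives 8350 nM in this assay. Compound 1 gives 10500 nM in this assay, which is within the scatter of compound 2, so the two numbers show no separation. Compound 3 `Cc1cccc(Nc2nc(SCc3cn(Cc4ccccc4Cl)nn3)nc(-c3ccccc3)c2C#N)c1` is the next member: 3-methylphenyl in place of 2-chlorophenyl on a nitrogen on an aromatic ring. Going by the values given here, both groups carry the same counts of donors and acceptors, and no step between measured compounds informs this change, so no step beyond the scatter is expected from compound 2 to compound 3 in this assay, namely a 1.0-fold lower number from compound 2 to compound 3 (0.02 log units; within the scatter). Compound 3 is estimated at 8000 nM in this assay, with a range of 3000 nM to 20000 nM.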

Compound 3, half-maximal inhibitory concentration: 13500 nM
For compound 3 the middle estimate is 1.7-fold (0.23 log units) below the measured one; the measured number falls inside the stated range.
By their numbers in this assay, from the lowest: compounds 2, 1 and 3 (each within the scatter of the next).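

In this assay, 3-methylphenyl in place of 2-chlorophenyl on a nitrogen on an aromatic ring gives a 1.6-fold higher number from compound 2 to compound 3 (0.21 log units; within the scatter), the first step read at this position. This swap of one substituted phenyl for another therefore leaves the two compounds unseparated, and neither group stands out here. No measured evidence bears on this result.

Open, from the compounds shown here alone, is whether a different group on that nitrogen, such as a carboxylic acid-bearing phenyl or a saturated amine ring, would move the number beyond the scatter.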